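The compounds below may be only part of what the source reports. "The series", "measured", "known", "first", "only" and "open" are said of these compounds alone.

Compound 1 `COc1ccc(CNc2cc(OC)c(OC)c(OC)c2)cc1[N+](=O)[O-]`: in a functional assay on MGC-803 cells (Homo sapiens) for inhibition, read by MTT assay, with a stated time of 48 h (on this read-out higher numbers stand for weaker inhibition and lower numbers for stronger inhibition), compound 1 gives 19400 nM.
Compound 2 `COc1ccc(CN(C(=O)C=C(C)C)c2cc(OC)c(OC)c(OC)c2)cc1O`: in this assay compound 2 gives 320 nM.
Compound 3 `C/C=C/C(=O)N(Cc1ccc(OC)c(N)c1)c1cc(OC)c(OC)c(OC)c1`: in this assay compound 3 gives 150 nM.

Of these three, compound 2 stands second highest in this assay. Its nearest neighbour is compound 3, whose number is lower by a margin beyond the usual scatter, so compound 3 inhibits the cells more strongly than compound 2. Compound 1, which carries no acyl group on the nitrogen at all, lies far above both, and is by a wide margin the weakest inhibitor shown here.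

The next compound, compound 4 `CCC(=O)N(Cc1ccc(OC)c(O)c1)c1cc(OC)c(OC)c(OC)c1`, keeps the whole frame of compound 2 and alters only the acyl group on the nitrogen: ethyl in place of 2-methylprop-1-en-1-yl on a carbonyl carbon. The double bond outside the aromatic rings is gone and the chain is shorter.

For the measured compounds named here, no measured pair shows exactly this change, so the expectation rests on the general picture: both acylated compounds, compound 2 and compound 3, carry an unsaturated acyl group and both inhibit far more strongly than compound 1. Whether the saturated ethyl chain keeps that is uncertain; a modest loss in inhibition, beyond the scatter, is expected for compound 4, as the step of a 2.5-fold higher number from compound 2 to compound 4 (0.40 log units; beyond the scatter) expresses. For compound 4 the expected value in this assay is 800 nM, within a range from 250 nM to 3000 nM.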

Compound 4, half-maximal inhibitory concentration: 50 nM
Beside the measured number, compound 4's estimate is 16-fold (1.20 log units) above it, outside the stated range (below it).
By their numbers in this assay, from the lowest: compound 4; then compound 3; then compound 2; then compound 1.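

On a carbonyl carbon whose other neighbour is the amide-type nitrogen, the acyl group does not need a double bond outside the aromatic rings to inhibit these cells strongly. In this assay, replacing 2-methylprop-1-en-1-yl with ethyl gives a 6.4-fold lower number from compound 2 to compound 4 (0.81 log units; beyond the scatter), so this change goes toward stronger inhibition by a margin larger than the usual scatter. For the compounds shown here, this is the first direct reading of the position, as no earlier pair differed in one place only, but no measurement here explains why the shorter saturated chain gives the lower number.

With a single step at this position, there is no way to tell whether the trend continues with a methyl group or reverses with a longer chain such as butyl, or how an acyl chain ending in an amine or a carboxylic acid would behave. On these data alone, it also remains open whether propanoyl in place of the unsaturated acyl group of compound 3 would lower the number in the same way when the core carries an amino group instead of a hydroxyl group.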